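The source may report more compounds than this note shows. Statements on the series, on what has been measured and on what is new or still open speak of the compounds shown alone.

Compound 1 `C=C(Br)C(=O)Nc1ccc(/C=C2\SC(=O)N(Cc3ccc(Cl)cc3)C2=O)cc1` gives 2300 nM in a functional assay on HeLa cells (Homo sapiens) for cytotoxicity, read by cell counting, with a stated time of 4 days; on this read-out higher numbers stand for weaker inhibition and lower numbers for stronger inhibition. Compound 2 `C=C(Br)C(=O)Nc1ccc(/C=C2\SC(=O)N(Cc3ccc(C(C)(C)C)cc3)C2=O)cc1` carries tert-butyl in place of chloro on an aromatic carbon, and in this assay compound 2 gives 2700 nM, so that a 1.2-fold higher number from compound 1 to compound 2 (0.07 log units; within the scatter). Compound 3 `C=C(Br)C(=O)Nc1cccc(/C=C2\SC(=O)N(Cc3ccc(Cl)cc3)C2=O)c1` gives 2700 nM in this assay; the difference between the core of compound 3 and the core of compound 1 is not broken down here, and their two values sit within the scatter of each other. Compound 4 `C=C(Br)C(=O)Nc1cccc(/C=C2\SC(=O)N(Cc3ccc(C(C)(C)C)cc3)C2=O)c1` has not yet been measured; it differs from compound 3 by tert-butyl in place of chloro on an aromatic carbon, the same change as from compound 1 to compound 2. Because that change gave a 1.2-fold higher number from compound 1 to compound 2 (0.07 log units; within the scatter), the step from compound 3 to compound 4 is expected to be small as well, about a 1.1-fold higher number from compound 3 to compound 4 (0.05 log units; within the scatter). Compound 4 is therefore estimated at 3000 nM in this assay, with a likely range from 1500 nM to 6500 nM.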

Compound 4, half-maximal inhibitory concentration: 2800 nM
The estimate for compound 4 lay 1.1-fold (0.03 log units) above the measured number; the measured number falls inside the stated range.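

In this assay, tert-butyl in place of chloro on the core of compound 3 gives a 1.0-fold higher number from compound 3 to compound 4 (0.02 log units; within the scatter), and the two cores agree on this change: the same change on two cores in this assay, a 1.2-fold higher number (0.07 log units; within the scatter) from compound 1 to compound 2 and a 1.0-fold higher number (0.02 log units; within the scatter) from compound 3 to compound 4, 1.1-fold (0.05 log units) apart, within the scatter of two such steps. On these two cores, then, the swap from 4-chlorophenyl to 4-(tert-butyl)phenyl carries over as a step within the scatter. This does not show that it would carry over to any other core, and since both steps lie within the scatter, the agreement is between two near-null results and not between two clear effects.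

As far as these compounds go, whether an amine, a carboxylic acid or a longer chain in that place would behave the same stays open. So does what such a group would do on either core.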